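A few compounds are considered here, and "the series" means these few. Any claim that something is new, unique, unknown or untested is made for them only; others in the source may bear on it.

In a physicochemical assay for solubility (a lower number here means a less soluble compound, a higher number a more soluble compound), three compounds have been measured so far.

Compound 1, `O=C(Nc1ccc([N+](=O)[O-])cc1)c1cc(Cl)ccc1O`, gives 6.4 ug/mL.
Compound 2, `O=C(Nc1ccc([N+](=O)[O-])c(Cl)c1)c1cc(Cl)ccc1O`, gives only a limit of the assay, < 1 ug/mL.
Compound 3, `O=C(Nc1ccc(F)cc1Cl)c1cc(Cl)ccc1O`, gives 1.2 ug/mL.

Compound 1 and compound 2 differ in one place: chloro in place of hydrogen on an aromatic carbon. This change gave an at least 6.4-fold lower number from compound 1 to compound 2 (0.80 log units; beyond the scatter), a step that runs into (the limit of < 1 ug/mL in this assay, at which 1 of the 3 values shown sits), so its true size is not known. Compound 3 stands lowest of the two plain numbers, with compound 1 sitting higher; how the core of compound 3 differs from the core of compound 1 is not broken down here.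

Compound 4, `O=C(Nc1c(Cl)cc(F)cc1Cl)c1cc(Cl)ccc1O`, is not yet measured. It differs from compound 3 in one place: chloro in place of hydrogen on an aromatic carbon. Among the measured compounds shown here, this is the same kind of change as the one from compound 1 to compound 2, but its surroundings differ: in compound 2 the chloro entered ortho to a nitro group and meta to a large group, whereas in compound 4 it enters ortho to a large group and meta to a chloro group and a fluoro group. For the measured compounds named here, because the one measured example of this change gave an at least 6.4-fold lower number from compound 1 to compound 2 (0.80 log units; beyond the scatter), the expectation for compound 4 is a step of about a 4.0-fold lower number from compound 3 to compound 4 (0.60 log units; beyond the scatter) in this assay. Compound 4 is therefore estimated at 0.3 ug/mL, between 0.08 ug/mL and 1.2 ug/mL, most likely appearing only as a limit.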

Compound 4, solubility: > 49 ug/mL
Compound 4: a limit, no number; the forecaster's own chance of this, stated with the estimate: 70%; middle value at least 160-fold (2.21 log units) away from the limit.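

In this assay, chloro in place of hydrogen on an aromatic carbon gave an at least 40-fold higher number from compound 3 to compound 4 (1.61 log units; beyond the scatter), whereas the same change on the core of compound 1 gave an at least 6.4-fold lower number from compound 1 to compound 2 (0.80 log units; beyond the scatter), so the effect seen on one core did not carry over to the other and the two steps run in opposite directions. Compound 4 gives > 49 ug/mL, which is a limit of the assay and not a number, so the size of its step has a floor but no known true value: the limit of > 49 ug/mL in this assay, at which 1 of the 4 values shown sits. These two examples show that the same written change can go either way in this series, but they give no rule for any other core and do not show which difference between the two cores, or between the places where chloro enters, decides the direction.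

The compounds shown leave open whether a chloro ortho to a large group on the core of compound 1 would also give a higher number, a comparison that would help separate the effect of the place from the effect of the core. They also leave open whether a different entering group at that place, such as a methyl, a methoxy or an amine, would follow the same direction as chloro.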